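Changing the Acid-Bearing Ring on a Shared Core

The source may report more compounds than this note shows. Statements on the series, on what has been measured and on what is new or still open speak of the compounds shown alone.

Compound 1 `COc1ccc(/C=C\c2cc(OC)c(OC)c(OC)c2)cc1OCc1ccc(CN2CCCC[C@H]2C(=O)O)cc1` carries a 2-carboxypiperidin-1-yl group on a saturated chain carbon bound to an aromatic carbon. In a functional assay on HepG2 cells (Homo sapiens) for antiproliferative activity, read by CCK-8 assay, with a stated time of 48 h (on this read-out lower numbers stand for stronger inhibition and higher numbers for weaker inhibition), compound 1 gives > 10000 nM, which is a limit of the assay rather than a number. On the numbers shown, compound 1 therefore stands at the limit of > 10000 nM in this assay, at which 1 of the 2 values shown sits. The other measured compound, compound 2 `COc1ccc(/C=C\c2cc(OC)c(OC)c(OC)c2)cc1OCc1ccc(CN2CCCCC2C(=O)NCCNC(=O)OC(C)(C)C)cc1`, has the free acid replaced by an amide-linked chain, and in this assay compound 2 gives 1100 nM. Going by the values given here, no step between these two is drawn here, so their two values show only that compound 2 has a number while compound 1 has a limit.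

Compound 3 `COc1ccc(/C=C\c2cc(OC)c(OC)c(OC)c2)cc1OCc1ccc(CN2CC[C@H](C(=O)O)C2)cc1` is the not-yet-measured partner of compound 1. The change is 3-carboxypyrrolidin-1-yl in place of 2-carboxypiperidin-1-yl on a saturated chain carbon bound to an aromatic carbon. The free carboxylic acid stays; only the ring that carries it changes. The expected step in this assay from compound 1 to compound 3 is a step that the limit leaves unreadable from compound 1 to compound 3, none beyond the scatter, with compound 3 expected to remain near the limit. For compound 3 the estimate is 15000 nM, within a range from 5000 nM to 50000 nM.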

Compound 3, half-maximal inhibitory concentration: 6400 nM
Estimate against measurement, compound 3: 2.3-fold (0.37 log units) above, and the stated range covers the measured number.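

With 3-carboxypyrrolidin-1-yl in place of 2-carboxypiperidin-1-yl, a compound that keeps the free carboxylic acid on the shared core now has a measured number: in this assay, compound 3 gives 6400 nM. The ring change at this position on a saturated chain carbon bound to an aromatic carbon is read as an at least 1.5-fold lower number from compound 1 to compound 3 (0.19 log units; that floor lies within the scatter), so the data do not establish a gain beyond the scatter, although the true step could be larger. Its full size cannot be read because compound 1, at the other end of the step, is held at a limit rather than a number: the limit of > 10000 nM in this assay, at which 1 of the 3 values shown sits.

From the compounds shown here alone, it remains open what a methyl ester or a primary amide would give in place of the free carboxylic acid on the 3-carboxypyrrolidin-1-yl ring, and how the opposite arrangement at its stereocentre would read. A 3-carboxyazetidin-1-yl group, with a still smaller ring, or a 4-carboxypiperidin-1-yl group, with the acid moved around the six-membered ring, would also help separate the effect of ring size from that of the acid's placement.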